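What an Iodo Group May Do to Compound 2

The source may report more compounds than this note shows. Statements on the series, on what has been measured and on what is new or still open speak of the compounds shown alone.

Among the compounds with values here, only two compounds have been measured so far in a functional assay on U-87MG ATCC cells (Homo sapiens) for cytotoxicity, read by MTT assay, with a stated time of 48 h; on this read-out higher numbers stand for weaker inhibition and lower numbers for stronger inhibition. Compound 2 (`C/C(=N\NC(=S)Nc1ccccc1)c1ccccn1`) gives 1.4 nM, the lower of the two numbers and so the stronger inhibition. Compound 1 (`CC(=NNC(=S)Nc1cccc(I)c1)c1ccccn1`) gives 84 nM, and this gap lies beyond the usual scatter of repeated measurements.

Compound 3 (`C/C(=N\NC(=S)Nc1cccc(I)c1)c1ccccn1`) has not yet been measured. It is compound 2 with one structural change: iodo in place of hydrogen on an aromatic carbon, which means iodo in place of hydrogen on an aromatic carbon. Within the data shown here, no measured pair shows this change alone, so any forecast is tentative. Compound 1 also carries an iodo group, and its 84 nM is the best guide available. A clear weakening beyond the scatter is therefore expected, with an estimated step of a 43-fold higher number from compound 2 to compound 3 (1.63 log units; beyond the scatter). For compound 3 the estimated value is 60 nM, with an expected range of 10 nM to 200 nM.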

Compound 3, half-maximal inhibitory concentration: 84 nM
Estimate against measurement, compound 3: 1.4-fold (0.15 log units) below; measured number inside the range.
By their numbers in this assay, from the lowest: compound 2; then compounds 1 and 3 (each within the scatter of the next).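

Within the data shown here, this is the first direct reading of the iodo change on its own: iodo in place of hydrogen on an aromatic carbon, meta to a large group, gives a 60-fold higher number from compound 2 to compound 3 (1.78 log units; beyond the scatter) in this assay. At this place, then, a single iodine atom is enough to weaken inhibition by a large margin. The drawn configuration of the double bond adds nothing visible, with no change at the digits printed from compound 1 to compound 3 (within the scatter), and the comparison of these two compounds rests on one point: the fact that one of compounds 1 and 3 is drawn with a defined configuration and the other without, at the place where they differ

The compounds shown leave open whether the step belongs to iodo itself, or whether a chloro or a methoxy group on the same carbon would bring a step of similar size. They also leave open what iodo would do on another carbon of the same ring.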